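This account rests on a few compounds, and the source may have more. Where it says the series, first, only, none or still open, it means among the compounds named here.

Measured compounds:
Compound 1 `O=C(Nc1ccc(-c2noc(-c3cccc(NS(=O)(=O)c4ccccc4)c3)n2)c(Cl)c1)c1cccnc1` — in a functional assay on MDA-MB-231 cells (Homo sapiens) for antiproliferative activity, read by MTT assay, with a stated time of 72 h (on this read-out lower numbers stand for stronger inhibition and higher numbers for weaker inhibition), compound 1 gives > 10000 nM, which is a limit of the assay and not a number.
Compound 2 `NS(=O)(=O)c1ccc(S(=O)(=O)Nc2cccc(-c3nc(-c4ccc(NC(=O)c5cccnc5)cc4Cl)no3)c2)cc1` — in this assay compound 2 gives > 10000 nM, again only a limit.
Compound 3 `COc1cc(-c2noc(-c3cccc(NS(=O)(=O)c4ccc(NC(C)=O)cc4)c3)n2)ccc1NC(=O)c1cccnc1` — in this assay compound 3 gives > 10000 nM, also a limit.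

Compound 1 therefore stands nowhere that can be placed on a scale: its value is a limit, and the same holds for every other value shown, all of which sit at the limit of > 10000 nM in this assay, at which 3 of the 3 values shown sit. Among the measured compounds shown here, the only single-point step measured, a step that the two limits leave unreadable from compound 1 to compound 2, has no readable size because both of its ends rest at the limit of > 10000 nM in this assay, at which 3 of the 3 values shown sit.

Compound 4 `NC(=O)Nc1ccc(S(=O)(=O)Nc2cccc(-c3nc(-c4ccc(NC(=O)c5cccnc5)cc4Cl)no3)c2)cc1` differs from compound 1 by ureido in place of hydrogen on an aromatic carbon. The step from compound 1 to compound 2 is the nearest comparison, a different group entering at the same kind of place, and it gave nothing readable. For the measured compounds named here, no measured step in this assay thus sets a size or a direction for this change. The expectation is that compound 4 remains at the limit, so that a step that the limit leaves unreadable from compound 1 to compound 4 is estimated as no readable step. For compound 4 in this assay the estimate is 15000 nM, with a range from 5000 nM to 50000 nM.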

Compound 4, half-maximal inhibitory concentration: 2800 nM
Estimate against measurement, compound 4: 5.4-fold (0.73 log units) above; the measured number lies below the stated range.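

Ureido in place of hydrogen, on an aromatic carbon para to a large group, gives the only value off the limit among the compounds shown in this assay, with an at least 3.5-fold lower number from compound 1 to compound 4 (0.55 log units; beyond the scatter). Substitution at this place is not enough in itself, since the same place carries sulfamoyl in compound 2 and ureido in place of sulfamoyl gives an at least 3.5-fold lower number from compound 2 to compound 4 (0.55 log units; beyond the scatter), so the identity of the group matters here. Both steps are bounds and not sizes, because their starting compounds rest on a limit: the limit of > 10000 nM in this assay, at which 3 of the 4 values shown sit.

Going by these compounds, whether the change depends on the ureido group as a whole stays open, as an amine or a carboxylic acid at this place would be needed to show it. Also open, on these data alone, is how far a longer chain on the ureido nitrogen would carry the value in either direction.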